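Opening the Ring on a Sulfone-Bearing Amine

The compounds below may be only part of what the source reports. "The series", "measured", "known", "first", "only" and "open" are said of these compounds alone.

For the measured compounds named here, compound 2 `O=S(=O)(c1cccc(F)c1)c1ccc2c(c1)CCC[C@H]2CN1CCCS1(=O)=O` is one of two compounds measured in an assay on isolated protein for displacement of a labelled ligand from 5-hydroxytryptamine receptor 6 (Homo sapiens); a higher number here means a weaker inhibitor, a lower number a stronger inhibitor. In this assay compound 2 gives 31.6 nM, the higher of the two numbers. The other, compound 1 `CC(=N)NCC1CCCc2cc(S(=O)(=O)c3ccccc3)ccc21`, gives 0.631 nM in this assay, a lower number by a gap well beyond the usual scatter. Compound 3 `O=S(=O)(c1cccc(F)c1)c1ccc2c(c1)CCC[C@H]2CNCCO` has not yet been measured in this assay. Its difference from compound 2 is this: a group of 4 heavy atoms (2 carbon, 1 nitrogen, 1 oxygen; no ring) in place of a group of 7 heavy atoms (3 carbon, 1 nitrogen, 2 oxygen, 1 sulfur; one five-membered non-aromatic ring with 2 hetero atoms), on a saturated chain carbon bound to a saturated ring carbon. Going by the values given here, no step between two measured compounds that differ in one place is available to guide the expectation, since compound 1 and compound 2 differ in more than one place. The entering group is smaller and open-chain, and it carries hydrogen-bond donors where the leaving group carries none. Compound 3 is expected to give a lower number than compound 2, a step beyond the scatter, a 7.9-fold lower number from compound 2 to compound 3 (0.90 log units; beyond the scatter). The estimate for compound 3 in this assay is 4 nM, with a range from 0.8 nM to 20 nM.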

Compound 3, inhibition constant: 0.126 nM
Beside the measured number, compound 3's estimate is 32-fold (1.50 log units) above it, and the stated range ends above it.
By their numbers in this assay, from the lowest: compound 3; then compound 1; then compound 2.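

In this assay, the place on a saturated chain carbon bound to a saturated ring carbon turns out to be highly sensitive: putting (2-hydroxyethyl)amino there in place of the five-membered ring with its sulfur gives a 250-fold lower number from compound 2 to compound 3 (2.40 log units; beyond the scatter) in a single change. For the compounds shown here, the earlier compounds could not show this, as compound 1 and compound 2 differ in more than one place, so this is the first reading of one change at this position. Nothing at hand explains why the step is so large.

The compounds shown leave open which part of the (2-hydroxyethyl)amino group carries the step: the hydroxyl, the nitrogen with its hydrogen, or simply the open chain. A primary amine, a methoxyethylamino group or a longer chain ending in a hydroxyl at the same place would help to separate these.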